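Series notes: amide variation at the ester-side chain, solubility

The compounds below may be only part of what the source reports. "The series", "measured", "known", "first", "only" and "open" are said of these compounds alone.

Measured so far:
compound 2 `CCOc1cc(NC(=O)C2(NC(=O)c3ccc4c(C5CCCC5)c(-c5ncc(Cl)cn5)n(C)c4c3)CCC2)ccc1/C=C/C(=O)OCC(N)=O` — in an ADME assay for solubility (a higher number here means a more soluble compound, a lower number a less soluble compound), compound 2 gives < 200000 ug/mL
compound 1 `CCOc1cc(NC(=O)C2(NC(=O)c3ccc4c(C5CCCC5)c(-c5ncc(Cl)cn5)n(C)c4c3)CCC2)ccc1/C=C/C(=O)OCCOCCOC` — in this assay compound 1 gives < 60000 ug/mL

Compound 2 stands only at a limit of the assay, not at a number. For the measured compounds named here, the one other value shown, that of compound 1, is likewise a limit of the assay. The step that the two limits leave unreadable from compound 1 to compound 2 therefore cannot be sized: compound 1 sits at the limit of < 60000 ug/mL in this assay, at which 1 of the 2 values shown sits, and compound 2 at the limit of < 200000 ug/mL in this assay, at which 1 of the 2 values shown sits.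

Compound 3 `CCCN(C)C(=O)COC(=O)/C=C/c1ccc(NC(=O)C2(NC(=O)c3ccc4c(C5CCCC5)c(-c5ncc(Cl)cn5)n(C)c4c3)CCC2)cc1OCC` differs from compound 2 by methyl(propyl)amino in place of amino on a carbonyl carbon. Going by the values given here, the only measured step is that from compound 1 to compound 2, and it reads as unreadable in this assay, so no measured step bears on the present change. For this assay no step beyond the scatter is expected from compound 2 to compound 3, and the estimated step is a step that the limit leaves unreadable from compound 2 to compound 3. Compound 3 is expected at 60000 ug/mL, within 10000 ug/mL to 200000 ug/mL, most likely again reported as a limit.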

Compound 3, solubility: < 200000 ug/mL
Compound 3: only a limit was reported; the forecaster's own chance of this, stated with the estimate: 70%; the middle value does not contradict the limit.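

In this assay compound 3 gives < 200000 ug/mL, a limit of the assay and not a number. For the compounds shown here, no step from compound 1 or compound 2 to compound 3 can be read. The compounds shown leave open whether methyl(propyl)amino in place of amino on a carbonyl carbon shifts the reading in this assay at all.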